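This account rests on a few compounds, and the source may have more. Where it says the series, first, only, none or still open, it means among the compounds named here.

Compound 3 `NC(=O)c1cccc(-c2cc(C(O)(C(F)(F)F)C(F)(F)F)cnc2N2CCN(S(=O)(=O)c3ccc(N)nc3)CC2)c1` sits at the lower end of the numbers reported so far: in an ADME assay (liver) for metabolic stability, with Liver microsome (Homo sapiens) as the target, using microsomes and NADPH, with a stated time of 30 min, tested at 1 uM (on this read-out higher numbers stand for fast clearance and lower numbers for slow clearance), compound 3 gives 17 mL.min-1.g-1. Compound 2 `Nc1ccc(S(=O)(=O)N2CCN(c3ncc(C(O)(C(F)(F)F)C(F)(F)F)cc3-c3ccccc3O)CC2)cn1` gives 22 mL.min-1.g-1 in this assay, and the difference a 1.3-fold lower number from compound 2 to compound 3 (0.11 log units; within the scatter) is too small to count. Compound 1 `Nc1ccc(S(=O)(=O)N2CCN(c3ncc(C(O)(C(F)(F)F)C(F)(F)F)cc3C#CC3CC3)CC2)cn1` gives < 14 mL.min-1.g-1 in this assay, which is a limit of the measurement rather than a number (the limit of < 14 mL.min-1.g-1 in this assay, at which 1 of the 3 values shown sits). From there to compound 3 the step of an at least 1.2-fold higher number from compound 1 to compound 3 (0.08 log units; that floor lies within the scatter) and to compound 2 the step of an at least 1.5-fold higher number from compound 1 to compound 2 (0.19 log units; that floor lies within the scatter) are both at least modest rises, though their floors lie within the scatter.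

Compound 4 `Cc1nc2cc(-c3cc(C(O)(C(F)(F)F)C(F)(F)F)cnc3N3CCN(S(=O)(=O)c4ccc(N)nc4)CC3)ccc2o1` differs from compound 3 at one aromatic carbon of the shared core: 2-methyl-1,3-benzoxazol-5-yl in place of 3-carbamoylphenyl on an aromatic carbon.

The nearest guide is the swap among aryl groups at that carbon, which moved this assay only within the scatter. A bicyclic aromatic group with no donor replaces an amide-bearing ring, and the change is expected to leave clearance near where it was, perhaps a little faster, giving an expected step of a 1.3-fold higher number from compound 3 to compound 4 (0.11 log units; within the scatter). Compound 4 is therefore estimated at 22 mL.min-1.g-1, likely between 11 mL.min-1.g-1 and 45 mL.min-1.g-1.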

Compound 4, intrinsic clearance in microsomes: < 14 mL.min-1.g-1
Compound 4: only a limit was reported; the forecaster's own chance of this, stated with the estimate: 15%; at least 1.5-fold (0.19 log units) between middle value and limit.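

In this assay compound 4 gives < 14 mL.min-1.g-1, which is a limit and not a number. This aromatic carbon of the shared core accepts 2-methyl-1,3-benzoxazol-5-yl, a two-ring group with no hydrogen-bond donor, with no rise in the number, as the steps show: an at least 1.2-fold lower number from compound 3 to compound 4 (0.08 log units; that floor lies within the scatter) and an at least 1.5-fold lower number from compound 2 to compound 4 (0.19 log units; that floor lies within the scatter); the floors of both lie within the scatter, so neither step alone establishes slower clearance. The step between compound 1 and compound 4 cannot be read because both compounds rest on one limit: the limit of < 14 mL.min-1.g-1 in this assay, at which 2 of the 4 values shown sit.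

On these data alone, how far the true clearance of compound 4 lies under that limit stays open. Also open, as far as these compounds go, are whether the 2-methyl group on the new ring matters and how a carboxylic acid in place of the carbamoyl group of compound 3 would read in this assay.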